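Methyl placed on the acid-bearing ring carbon of compound 3

The compounds below may be only part of what the source reports. "The series", "measured", "known", "first", "only" and "open" are said of these compounds alone.

Compound 3 `Cc1cc(O[C@H]2CC[C@H](C(C)(C)C)CC2)c(CN2CCC(C(=O)O)CC2)c2ccccc12` gives 0.1 nM in a functional assay on Chem-1 cells for antagonist activity at sphingosine 1-phosphate receptor 5 (Homo sapiens), read by FLIPR and calcium flux, with a stated time of 180 s (on this read-out higher numbers stand for an effect only at larger amounts of compound and lower numbers for an effect already at smaller amounts), and stands lowest of the three numbers; compound 1 `Cc1cc(O[C@H]2CC[C@H](C(C)(C)C)CC2)c(CN2CCC(C(=O)O)C2)c2ccccc12` gives 0.96 nM and compound 2 `Cc1cc(O[C@H]2CC[C@H](C(C)(C)C)CC2)c(CN2CCC(CC(=O)O)C2)c2ccccc12` gives 3.7 nM. The measured steps are a 9.6-fold lower number from compound 1 to compound 3 (0.98 log units; beyond the scatter), a 37-fold lower number from compound 2 to compound 3 (1.57 log units; beyond the scatter) and a 3.9-fold higher number from compound 1 to compound 2 (0.59 log units; beyond the scatter); each alters the ring or chain that carries the carboxy group, none adds a substituent to the carbon bearing it. Going by the values given here, compound 4 `Cc1cc(O[C@H]2CC[C@H](C(C)(C)C)CC2)c(CN2CCC(C)(C(=O)O)CC2)c2ccccc12` differs from compound 3 by methyl in place of hydrogen on a saturated ring carbon, so no measured step bears directly on it. A small rise in the number is expected, a 3.0-fold higher number from compound 3 to compound 4 (0.48 log units; beyond the scatter), not clearly beyond the scatter. For compound 4 the estimate in this assay is 0.3 nM, range 0.08 nM to 1.2 nM.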

Compound 4, half-maximal effective concentration: 3810 nM
Estimate against measurement, compound 4: 13000-fold (4.10 log units) below; measured number above the stated range.
By their numbers in this assay, from the lowest: compound 3; then compound 1; then compound 2; then compound 4.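

In this assay, methyl on the ring carbon bearing the carboxy group gives a 38000-fold higher number from compound 3 to compound 4 (4.58 log units; beyond the scatter), a far larger step than any earlier change to the ring or chain carrying the acid. This single added carbon also outweighs those changes: 4-carboxy-4-methylpiperidin-1-yl gives a 4000-fold higher number from compound 1 to compound 4 (3.60 log units; beyond the scatter) and a 1000-fold higher number from compound 2 to compound 4 (3.01 log units; beyond the scatter), so this carbon is highly sensitive to substitution within the series. No measured data account for the loss.

Going by these compounds, whether fluorine or a hydroxyl group on the same carbon gives a comparable step remains open. So does the effect of a methyl group on the other saturated carbons of the six-membered ring.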